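The source may hold more compounds than are shown below. What is called first, only, known or untested is meant among the compounds shown, and "the series" means these compounds.

Measured in a functional assay on ECa-109 cells for inhibition, with ECa-109 cell line (Homo sapiens) as the target, read by sulforhodamine B assay; on this read-out lower numbers stand for stronger inhibition and higher numbers for weaker inhibition:
Compound 1 `CCCc1ccc(NC2=CC(=O)c3nc4n(c3C2=O)[C@H]2OC[C@@H](O)[C@H]2OC4)cc1`: > 4000 nM, a limit
Compound 2 `O=C1C=C(NC2CCCCC2)C(=O)c2c1nc1n2[C@H]2OC[C@@H](O)[C@H]2OC1`: > 16000 nM, a limit
Compound 3 `CCOc1ccc(NC2=CC(=O)c3nc4n(c3C2=O)[C@H]2OC[C@@H](O)[C@H]2OC4)cc1`: 3210 nM

Compound 2 has no exact number here, only the limit > 16000 nM. Compound 4 `CCCN(CCC)C1=CC(=O)c2nc3n(c2C1=O)[C@H]1OC[C@@H](O)[C@H]1OC3` keeps the shared core of compound 2 and has dipropylamino in place of cyclohexylamino on a double-bonded ring carbon. The new group has no ring and no hydrogen-bond donor.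

Two measured steps start or end at compound 2. One cannot be sized, since both its ends are limits: a step that the two limits leave unreadable from compound 1 to compound 2. The other is readable: an at least 4.9-fold lower number from compound 2 to compound 3 (0.69 log units; beyond the scatter). That step brings in 4-ethoxyphenyl, an aromatic group, and dipropylamino brings in nothing of that kind. Within the data shown here, no measured step removes the hydrogen-bond donor, so the data give no direct guide to that part of the change.

In this assay, no clear shift is therefore expected, and the estimated step is a number no higher from compound 2 to compound 4 (the limit leaves the size open). The expected value for compound 4 is 16000 nM, within an estimated range from 6000 nM to 40000 nM. A reading that is only a limit would be no surprise.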

Compound 4, half-maximal inhibitory concentration: > 16000 nM
Compound 4: no number, only a limit; the forecaster's own chance of this, stated with the estimate: 55%; the middle value sits exactly at the limit.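

Compound 2 and compound 4 each give only a limit in this assay, so the step between them cannot be read: the limit of > 16000 nM in this assay, at which 2 of the 4 values shown sit. The compounds shown leave open whether swapping cyclohexylamino for dipropylamino, which removes the hydrogen-bond donor, changes inhibition at all.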